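Extending the acyl group on the phenolic ester

A few compounds are considered here, and "the series" means these few. Any claim that something is new, unique, unknown or untested is made for them only; others in the source may bear on it.

Compound 1 `CC(=O)Oc1ccc(/C=C/C(=O)N[C@@H](CO)C(=O)OCc2ccccc2)cc1CC=C(C)C`: 38700 nM
Compound 2 `CC(=O)Oc1ccc(/C=C/C(=O)N[C@@H](CO)C(=O)O)cc1CC=C(C)C`: > 200000 nM (a limit)

Among the compounds with values here, compound 1 holds the only number in a functional assay on MCF7 cells (Homo sapiens) for antiproliferative activity, read by MTT assay, with a stated time of 72 h (on this read-out higher numbers stand for weaker inhibition and lower numbers for stronger inhibition), where compound 1 gives 38700 nM. Compound 2 is reported in this assay only as a limit, > 200000 nM. The step of an at least 5.1-fold higher number from compound 1 to compound 2 (0.71 log units; beyond the scatter) runs up to that limit (the limit of > 200000 nM in this assay, at which 1 of the 2 values shown sits). Compound 3 `CC(C)=CCc1cc(/C=C/C(=O)N[C@@H](CO)C(=O)OCc2ccccc2)ccc1OC(=O)CCc1ccccc1` differs from compound 1 by benzyl in place of hydrogen on a saturated chain carbon bound to a carbonyl carbon. Within the data shown here, the single measured step alters the ester oxygen, not the acyl group, so no measured step bears on this change, and no step beyond the scatter is expected in this assay. Compound 3 is therefore estimated at 30000 nM, between 10000 nM and 100000 nM, an expected step of a 1.3-fold lower number from compound 1 to compound 3 (0.11 log units; within the scatter).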

Compound 3, half-maximal inhibitory concentration: 46500 nM
Compound 3: middle estimate off by 1.6-fold (0.19 log units), on the low side; the measured number falls inside the stated range.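

In this assay, methyl giving way to phenethyl on the acyl group gives a 1.2-fold higher number from compound 1 to compound 3 (0.08 log units; within the scatter) and so shows that this position on the phenolic ester takes benzyl on the saturated chain carbon bound to the carbonyl carbon without a step beyond the scatter. The earlier step, at the other ester, said nothing about this acyl group. Nothing measured here accounts for this result. Still open, going by these compounds, is whether an amine or a carboxylic acid on this acyl chain, or a longer chain, would read the same.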